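The source may report more compounds than this note shows. Statements on the series, on what has been measured and on what is new or still open speak of the compounds shown alone.

Values measured so far in an ADME assay on microsomes from liver (Homo sapiens) for metabolic stability, read by LC-MS, using NADPH, with stated times of 5 min and 30 min, tested at 1 uM (on this read-out higher numbers stand for fast clearance and lower numbers for slow clearance), are as follows.

Compound 1 `CN(c1ncco1)c1cnc(NCc2c(F)ccc3c2CCO3)n2cnnc12` gives 11 mL.min-1.g-1
Compound 2 `Cn1nccc1-c1cnc(NCc2c(F)ccc3c2CCO3)c2cn[nH]c(=O)c12` gives 14 mL.min-1.g-1
Compound 3 `Cc1ncccc1-c1cnc(NCc2c(F)ccc3c2CCO3)c2n[nH]c(=O)n12` gives 8 mL.min-1.g-1

These three compounds share a substituted benzylamine-like side group, though their cores and other groups differ. Compound 2 cannot be told apart from compound 1 or from compound 3, since its value lies within the usual scatter of both. For a newcomer, this means that the small gaps between these numbers should not be read as real differences.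

Compound 4 `Cc1ncccc1-c1cnc(NCc2c(F)ccc3c2CCO3)c2cn[nH]c(=O)c12` has not yet been measured. It differs from compound 2 in one place, with 2-methylpyridin-3-yl in place of 1-methyl-1H-pyrazol-5-yl on an aromatic carbon and the core unchanged.

For the measured compounds named here, no two measured compounds differ in only one place, so the effect of this swap cannot be read directly from the data. The nearest guide is compound 3, which carries the same 2-methylpyridin-3-yl on another core and gives 8 mL.min-1.g-1 in this assay as its value. A change beyond the scatter therefore seems unlikely. The expected result is a 1.3-fold lower number from compound 2 to compound 4 (0.10 log units; within the scatter) and this estimated step stays within the scatter.

Compound 4 is expected to give 11 mL.min-1.g-1 as its value, with an estimated range from 6 mL.min-1.g-1 to 20 mL.min-1.g-1 in this measurement.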

Compound 4, intrinsic clearance in microsomes: 41 mL.min-1.g-1
For compound 4 the middle estimate is 3.7-fold (0.57 log units) below the measured one; measured number outside the range, above it.
By their numbers in this assay, from the lowest: compounds 3, 1 and 2 (each within the scatter of the next); then compound 4.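

In this assay, the group on this aromatic carbon clearly matters on this core: 2-methylpyridin-3-yl in place of 1-methyl-1H-pyrazol-5-yl gives a 2.9-fold higher number from compound 2 to compound 4 (0.47 log units; beyond the scatter) and so moves the compound toward faster clearance. For the compounds shown here, until now, no pair of compounds differing in one place could show this, and the numbers alone could not separate any of the earlier compounds from one another. No measurement shown here explains why the number rises with this swap.

The compounds shown leave open whether the higher number goes with the six-membered ring itself or with the methyl group on it; a pyridin-3-yl without that methyl, or a plain phenyl, at the same place would help to separate the two. From the compounds shown here alone, it also remains open whether the same swap would give a step of similar size on the core of compound 3, since a single pair speaks only for the core of compound 2 and compound 4.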